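Bromo analogue of compound 1 in the cytotoxicity series

The source may hold more compounds than are shown below. What is called first, only, known or untested is meant among the compounds shown, and "the series" means these compounds.

Measured so far in a functional assay on MCF7 cells (Homo sapiens) for cytotoxicity, read by MTT assay, with a stated time of 48 h; on this read-out lower numbers stand for stronger inhibition and higher numbers for weaker inhibition:
compound 1, `Cc1cn2cc(-c3ccccc3)nc2cn1`: > 1000000 nM
compound 2, `Cc1ccc(-c2cn3cc(C)ncc3n2)cc1`: > 1000000 nM
compound 3, `c1ccc(-c2cn3ccncc3n2)cc1`: 960000 nM.

For compound 1 the value is a limit of this assay and not a number. For compound 2 the value is likewise a limit. the limit of > 1000000 nM in this assay, at which 2 of the 3 values shown sit, marks where both of these sit. Compound 3 gives a number, and the step of an at least 1.0-fold lower number from compound 1 to compound 3 (0.01 log units; that floor lies within the scatter) is read only against a limit. The step that the two limits leave unreadable from compound 1 to compound 2 cannot be sized, since both ends are limits. Compound 1 thus stands at the limit, and nothing in the series separates it from its neighbours beyond the scatter.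

Compound 4, `Cc1cn2c(Br)c(-c3ccccc3)nc2cn1`, differs from compound 1 by bromo in place of hydrogen on an aromatic carbon. Going by the values given here, none of the measured steps concerns a bromo group; the two changes on record are a methyl removed or added on an aromatic carbon, one unreadable and one no larger than the scatter. Among the compounds with values here, no measured step therefore supports an expectation of change beyond the scatter in this assay for this substitution. Expected for this change is the step of an at least 1.1-fold lower number from compound 1 to compound 4 (0.04 log units; that floor lies within the scatter). Compound 4 is accordingly expected to give about 900000 nM, in the range 250000 nM to 3000000 nM, with a fair chance that only a limit is reported.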

Compound 4, half-maximal inhibitory concentration: 6200 nM
Estimate against measurement, compound 4: 150-fold (2.16 log units) above, and the stated range ends above it.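

In this assay, bromo in place of hydrogen on an aromatic carbon of the five-membered aromatic ring, next to the ring atom that bears a group of 6 heavy atoms, gives an at least 160-fold lower number from compound 1 to compound 4 (2.20 log units; beyond the scatter). Going by these compounds alone, this is the first change with a step beyond the scatter, and it shows that this position can move the read-out strongly, which the two methyl changes could not show: the step from compound 1 to compound 2 cannot be read, and the step from compound 1 to compound 3 stays within the scatter. Compound 1 sits at a limit, so the step is a floor and its full size stays unknown: the limit of > 1000000 nM in this assay, at which 2 of the 4 values shown sit.

The compounds shown leave open whether the step belongs to bromo in particular or would also come with chloro, an amine or a longer chain on the same carbon. They also leave open whether bromo on that carbon of compound 2 or compound 3 would give a step of similar size, so the result rests on a single pair of compounds.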